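The compounds below may be only part of what the source reports. "The series", "measured", "known", "first", "only" and "open" are said of these compounds alone.

Compound 1 `O=C(Nc1ccccc1)OC(COc1ccc(Cl)cc1)Cn1cncn1` gives 46%
Compound 2 `COc1ccc(OCC(Cn2cncn2)OC(=O)Nc2ccc(Cl)cc2)cc1` gives 49%
Compound 3 `O=C(Nc1ccccc1)OC(COc1ccccc1)Cn1ccnc1` gives 27%

These three values come from an assay on isolated protein for inhibition of Aromatase (Homo sapiens), with stated times of 1 min and 60 min, tested at 1 uM; a higher number here means more inhibition at the concentration tested (going by the name of the read-out), a lower number less inhibition. Compound 3 stands lowest of the three numbers; the nearest, compound 1, lies above it by more than the scatter, and compound 2 lies further above still. Compound 4 `O=C(Nc1ccc(Cl)cc1)OC(COc1ccccc1)Cn1ccnc1` differs from compound 3 in a single place: chloro in place of hydrogen on an aromatic carbon. Among the measured compounds shown here, no measured pair shows this change on its own; compounds 1 and 2 each carry a chloro and give the higher numbers, but both also differ from compound 3 elsewhere, so their values only suggest a direction. A moderate rise, at the edge of the scatter, is expected from compound 3 to compound 4, a number 11 percentage points higher from compound 3 to compound 4 (beyond the scatter). Compound 4 is therefore estimated at 38%, between 22% and 55%.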

Compound 4, a percentage reported as inhibition, at one concentration (the size of the read-out at that concentration, not a potency): 72%
Beside the measured number, compound 4's estimate is 34 percentage points below it, and the stated range ends below it.
By their numbers in this assay, from the lowest: compound 3; then compounds 1 and 2 (each within the scatter of the next); then compound 4.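

Among the compounds shown here, this is the first view of the change on its own: in this assay, chloro in place of hydrogen on an aromatic carbon, para to a large group, gives a number 45 percentage points higher from compound 3 to compound 4 (beyond the scatter). The step is large, which shows that this single position of the anilino group can by itself move the read-out well beyond the scatter. Nothing measured here accounts for the size of this step.

On these data alone, whether fluoro, bromo or trifluoromethyl at this position would bring a similar rise remains open. So does whether chloro at this position would bring a rise of this size on the core of compound 1.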